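The source may report more compounds than this note shows. Statements on the series, on what has been measured and on what is new or still open speak of the compounds shown alone.

Measured in an ADME assay on microsomes from liver (Homo sapiens) for metabolic stability, read by LC-MS, using NADPH, with a stated time of 60 min, tested at 0.1 uM; a lower number here means that less of the compound is left, a higher number that more of the compound is left:
- compound 1 `Fc1ccc(Nc2cc3[nH]c(Nc4ccc(N5CCN(CC6CC6)CC5)cn4)nc3cn2)cc1C(F)(F)F`: 52%
- compound 2 `Fc1ccc(Nc2cc3[nH]c(Nc4ccc(N5CCNCC5)cn4)nc3cn2)cc1F`: 92%
- compound 3 `Fc1ccc(Nc2cc3[nH]c(Nc4ccc(N5CCN(CC6CC6)CC5)cn4)nc3cn2)cc1F`: 7%

Of these three, compound 3 stands lowest at 7%, clearly under both of the others. The next structure, compound 4 `C[C@@H]1CN(c2ccc(Nc3nc4cnc(Nc5ccc(F)c(F)c5)cc4[nH]3)nc2)C[C@H](C)N1`, alters one part of compound 3: 3,5-dimethylpiperazin-1-yl in place of 4-(cyclopropylmethyl)piperazin-1-yl on an aromatic carbon. Here, 3,5-dimethylpiperazin-1-yl comes in place of 4-(cyclopropylmethyl)piperazin-1-yl on an aromatic carbon, para to a large group.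

The most relevant measured step is a number 85 percentage points lower from compound 2 to compound 3 (beyond the scatter), a large one, with cyclopropylmethyl in place of hydrogen on an amine nitrogen in a ring. Compound 4, like compound 2, has no cyclopropylmethyl group, so that step, read backwards, points to a large rise. The other step, a number 45 percentage points lower from compound 1 to compound 3 (beyond the scatter), is also large, but it concerns fluoro in place of trifluoromethyl on an aromatic carbon. Compound 4 keeps the fluoro of compound 3, so that step offers little guidance here.

Going by the values given here, no measured compound carries the 3,5-dimethylpiperazin-1-yl group, so the estimate is kept wide and set a little under compound 2 at 92%. The expected change is a number 71 percentage points higher from compound 3 to compound 4 (beyond the scatter). Compound 4 is estimated at 78%, with an expected range of 50% to 96%.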

Compound 4, percent of the compound remaining: 63%
Beside the measured number, compound 4's estimate is 15 percentage points above it, and the stated range covers the measured number.
By their numbers in this assay, from the lowest: compound 3; then compound 1; then compound 4; then compound 2.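

In this assay, 3,5-dimethylpiperazin-1-yl in place of 4-(cyclopropylmethyl)piperazin-1-yl gives a number 56 percentage points higher from compound 3 to compound 4 (beyond the scatter), so this place, on an aromatic carbon para to a large group, can carry a substituted piperazine ring and still keep much of the compound intact. The earlier compounds shown here showed only the effect of a group on the ring nitrogen, whereas the methyl groups of compound 4 also carry a cost, with a number 29 percentage points lower from compound 2 to compound 4 (beyond the scatter), although this modest step is smaller than the large a number 85 percentage points lower from compound 2 to compound 3 (beyond the scatter). Nothing measured here explains why the number moves with either change.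

Going by these compounds, whether the drop in compound 4 comes from the methyl groups together or from just one of them remains open, as does the role of its two defined stereocentres. Also open, on these data alone, is how this assay would read with a single methyl or a 2-hydroxyethyl chain on the piperazine nitrogen, or with a morpholine ring in place of the piperazine.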